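Diethylamino for piperidinyl on the aminomethyl arm

The source may hold more compounds than are shown below. What is called first, only, known or untested is meant among the compounds shown, and "the series" means these compounds.

Compound 3 `Cc1ccc2nc(/N=C3\C(=O)N(CN4CCCCC4)c4cccc(Cl)c43)sc2c1` gives 30200 nM in an ADME assay on MCF-10A cells (Homo sapiens) for cytotoxicity, read by sulforhodamine B assay, with a stated time of 48 h (on this read-out lower numbers stand for stronger inhibition of growth and higher numbers for weaker inhibition of growth), the second highest of the three numbers measured there. For the measured compounds named here, its nearest neighbour is compound 1 `Cc1ccc2nc(/N=C3\C(=O)N(CN4CCCCC4)c4cccc(Br)c43)sc2c1`, which in this assay gives 18400 nM; the only single-place step recorded, a 1.6-fold higher number from compound 1 to compound 3 (0.22 log units; within the scatter), lies within the scatter. Going by the values given here, the furthest value belongs to compound 2 `CCN(CC)CN1C(=O)C(=O)c2c(Br)cccc21`, which in this assay gives 113000 nM; it differs from compound 3 in more than one place, so no step is drawn between them.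

Compound 4 `CCN(CC)CN1C(=O)/C(=N\c2nc3ccc(C)cc3s2)c2c(Cl)cccc21` is not yet measured in this assay. Its difference from compound 3 is diethylamino in place of piperidin-1-yl on a saturated chain carbon bound to an amide-type nitrogen in a ring. Among the compounds with values here, no measured pair differs only in this way, so nothing speaks to the size of this change; the one recorded step, a 1.6-fold higher number from compound 1 to compound 3 (0.22 log units; within the scatter), concerns a different position and was within the scatter. The expectation is therefore a step of no more than the scatter, a 1.2-fold higher number from compound 3 to compound 4 (0.06 log units; within the scatter), in no preferred direction. Compound 4 is estimated at 35000 nM in this assay, with a range from 15000 nM to 80000 nM.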

Compound 4, concentration for 50% growth inhibition: 43900 nM
Compound 4: the middle estimate sits 1.3-fold (0.10 log units) below what was measured; measured number inside the range.
By their numbers in this assay, from the lowest: compounds 1, 3 and 4 (each within the scatter of the next, the first and the last beyond it); then compound 2.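

For the compounds shown here, this is the first pair that differs only on the aminomethyl arm, and in this assay the change of piperidin-1-yl to diethylamino, on a saturated chain carbon bound to an amide-type nitrogen in a ring, stays within the scatter (a 1.5-fold higher number from compound 3 to compound 4 (0.16 log units; within the scatter)). With the chloro group in place, the ring of the piperidin-1-yl group is therefore not needed to hold the number inside the scatter of compound 3, although this rests on a single pair. Nothing available on these compounds offers an explanation for the size of this step.

Whether the same exchange stays within the scatter with bromo in place of chloro remains open, as compound 1 has no diethylamino partner among the compounds shown. Also open, on these data alone, is whether an amine with a further hetero atom in the ring, such as morpholin-4-yl, or a longer chain between the ring nitrogen and the amine would move the number beyond the scatter.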